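Removing the nitro group from a cinnamamide that showed no activity

The source may report more compounds than this note shows. Statements on the series, on what has been measured and on what is new or still open speak of the compounds shown alone.

Measured so far:
compound 1, `COc1cccc(C(=O)Nc2cc(Sc3ncn[nH]3)c(O)c3ccccc23)c1`, in a functional assay on HCT-116 cells (Homo sapiens) for antiproliferative activity, read by MTT assay, with a stated time of 48 h; a higher number here means a weaker inhibitor, a lower number a stronger inhibitor: > 100000 nM
compound 2, `O=C(/C=C/c1ccc([N+](=O)[O-])cc1)Nc1cc(Sc2ncn[nH]2)c(O)c2ccccc12`, in this assay: > 100000 nM

Both numbers are limits of the assay, not measured values. For compound 1 the value > 100000 nM is only a limit. For compound 2 the value > 100000 nM is likewise only a limit, and it tells where compound 2 stands: at the edge of what the assay can report, where both measured compounds sit, as the summary the limit of > 100000 nM in this assay, at which 2 of the 2 values shown sit, shows.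

Compound 3, `O=C(/C=C/c1ccccc1)Nc1cc(Sc2ncn[nH]2)c(O)c2ccccc12`, is not yet measured. It differs from compound 2 in one place: hydrogen in place of nitro on an aromatic carbon. Among the measured compounds shown here, no step between two measured compounds is available to guide the expectation, so the change from compound 2 to compound 3 is expected to give no step beyond the scatter, a number no higher from compound 2 to compound 3 (the limit leaves the size open). Compound 3 is therefore expected to come in at about 100000 nM, in a range from 30000 nM to 300000 nM, most likely again as a limit.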

Compound 3, half-maximal inhibitory concentration: > 100000 nM
Compound 3: only a limit was reported; the forecaster's own chance of this, stated with the estimate: 75%; the middle value sits exactly at the limit.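

In this assay compound 3 gives > 100000 nM, which is only a limit. No step can therefore be read from compound 2 or compound 1 to compound 3: the limit of > 100000 nM in this assay, at which 3 of the 3 values shown sit.

The compounds shown leave open how strongly any of them acts, and whether they differ from one another at all.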